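Swapping a dihydrobenzofuran for an indane on a shared core

The source may report more compounds than this note shows. Statements on the series, on what has been measured and on what is new or still open speak of the compounds shown alone.

Of the compounds shown here, three have been measured in a physicochemical assay for solubility, read by HPLC, measured as thermodynamic solubility, with a stated time of 4 h, at pH 6.8 (a lower number here means a less soluble compound, a higher number a more soluble compound), and a fourth awaits its result. Compound 1 `Cn1c(COc2cccc(C(=O)O)c2)nc2ccc(Oc3ccc4c(c3)CCC4)nc21` gives 4.3 ug/mL in this assay. Compound 2 `Cn1c(COc2cccc(C(=O)O)c2)nc2ccc(Oc3ccc4c(c3)OCC4)nc21` gives 17 ug/mL in this assay. Compound 3 `Cn1c(COc2cccc(C(=O)O)c2)nc2cnc(Oc3ccc4c(c3)OCC4)cc21` gives 79 ug/mL in this assay, the highest number of the three.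

Compound 2 and compound 3 are built from the same atoms joined differently; the difference between their two cores is not broken down here. The step from compound 2 to compound 1 is a different kind of move: it exchanges the outer ring system while the core stays fixed. The change is this:

a group of 9 heavy atoms (9 carbon; one five-membered non-aromatic ring of carbon only, one six-membered aromatic ring of carbon only) in place of a group of 9 heavy atoms (8 carbon, 1 oxygen; one five-membered non-aromatic ring with 1 hetero atom, one six-membered aromatic ring of carbon only), on an oxygen on an aromatic ring

That exchange gave a 4.0-fold lower number from compound 2 to compound 1 (0.60 log units; beyond the scatter).

Compound 4 `Cn1c(COc2cccc(C(=O)O)c2)nc2cnc(Oc3ccc4c(c3)CCC4)cc21` is the unmeasured compound. It stands to compound 3 exactly as compound 1 stands to compound 2, with the same group leaving and the same group entering at the same kind of place: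

a group of 9 heavy atoms (9 carbon; one five-membered non-aromatic ring of carbon only, one six-membered aromatic ring of carbon only) in place of a group of 9 heavy atoms (8 carbon, 1 oxygen; one five-membered non-aromatic ring with 1 hetero atom, one six-membered aromatic ring of carbon only), on an oxygen on an aromatic ring

Going by the values given here, since this is the same change, and the only example of it measured so far gave a 4.0-fold lower number from compound 2 to compound 1 (0.60 log units; beyond the scatter), a step of about that size is expected again, so the estimated step is a 4.0-fold lower number from compound 3 to compound 4 (0.60 log units; beyond the scatter) from compound 3 to compound 4. The expectation rests on a single measured pair, so it carries real uncertainty. The estimated value for compound 4 in this assay is 20 ug/mL, with a likely range from 8 ug/mL to 45 ug/mL.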

Compound 4, solubility: 70 ug/mL
The estimate for compound 4 lay 3.5-fold (0.54 log units) below the measured number; the measured number lies above the stated range.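

On the shared core of compound 3 in this assay, replacing the group with an oxygen in its five-membered non-aromatic ring by 2,3-dihydro-1H-inden-5-yl gave a 1.1-fold lower number from compound 3 to compound 4 (0.05 log units; within the scatter) and so left the two compounds indistinguishable, whereas the same exchange on the core of compound 2 gave a 4.0-fold lower number from compound 2 to compound 1 (0.60 log units; beyond the scatter) and stood clear of the scatter. This shows that, for these two pairs, a step measured on one core did not carry over at the same size to the other, so one pair was a poor guide to the next, even though the group leaving, the group entering and the kind of place were all identical. It does not show how this exchange behaves on any further core or which core is the usual case, and nothing available here explains why the two pairs part ways.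

As far as these compounds go, whether the same difference between the two cores would appear with other groups on that oxygen, such as a plain phenyl ring or a ring carrying an amine, remains open. Also open, from the compounds shown here alone, is whether a third core would follow compound 1 and compound 2 or compound 3 and compound 4.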